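Swapping methylsulfonyl for methylsulfanyl on a shared core

A few compounds are considered here, and "the series" means these few. Any claim that something is new, unique, unknown or untested is made for them only; others in the source may bear on it.

Measured compounds:
Compound 1, `Cn1c(=O)c(=O)n(C2CCCC2)c2nc(N/N=C/c3ccc(S(C)(=O)=O)cc3)ncc21`: 26600 nM
Compound 2, `COc1ccc(/C=N/Nc2ncc3c(n2)n(C2CCCC2)c(=O)c(=O)n3C)cc1`: 26300 nM
Compound 3, `Cn1c(=O)c(=O)n(C2CCCC2)c2nc(N/N=C/c3ccccc3F)ncc21`: 27600 nM

All three compounds share one core and differ only in the aryl group hanging from the carbon with a double bond to nitrogen. In a functional assay on PC-3 cells (Homo sapiens) for antiproliferative activity, read by MTT assay (on this read-out higher numbers stand for weaker inhibition and lower numbers for stronger inhibition), compound 1 gives a number that cannot be told apart from those of compound 2 and compound 3: the step of a 1.0-fold lower number from compound 1 to compound 2 (0.00 log units; within the scatter) and the step of a 1.0-fold higher number from compound 1 to compound 3 (0.02 log units; within the scatter) are both flat, as is a 1.0-fold higher number from compound 2 to compound 3 (0.02 log units; within the scatter). So far, changing this aryl substituent has made no difference that rises above the scatter.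

Compound 4, `CSc1ccc(/C=N/Nc2ncc3c(n2)n(C2CCCC2)c(=O)c(=O)n3C)cc1`, is not yet measured. It differs from compound 1 as follows: methylsulfanyl in place of methylsulfonyl on an aromatic carbon. The three measured steps are the ones that bear on it, since each also alters the group on that phenyl ring, and each was flat. The expectation is therefore no step beyond the scatter, a 1.0-fold lower number from compound 1 to compound 4 (0.01 log units; within the scatter). Compound 4 is estimated at 26000 nM, within a range from 13000 nM to 55000 nM.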

Compound 4, half-maximal inhibitory concentration: 21000 nM
Compound 4: middle estimate off by 1.2-fold (0.09 log units), on the high side; low and high end bracket the measured number.
By their numbers in this assay, from the lowest: compounds 4, 2, 1 and 3 (each within the scatter of the next).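

In this assay, methylsulfanyl in place of methylsulfonyl on the aromatic carbon gives no change that can be told from the scatter (a 1.3-fold lower number from compound 1 to compound 4 (0.10 log units; within the scatter)). Methylsulfanyl has fewer heavy atoms, one hydrogen-bond acceptor instead of two, and none of the double bonds of methylsulfonyl, so this position tolerates that much difference in the group without a step beyond the scatter, and the same holds against the other two aryl groups (a 1.3-fold lower number from compound 2 to compound 4 (0.10 log units; within the scatter); a 1.3-fold lower number from compound 3 to compound 4 (0.12 log units; within the scatter)). Nothing available explains why these numbers stay so close.

On these data alone, whether an amine or a carboxylic acid on this phenyl ring would give a step beyond the scatter remains open. So does the effect of a longer chain in place of methylsulfanyl at this same position.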